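The source may report more compounds than this note shows. Statements on the series, on what has been measured and on what is new or still open speak of the compounds shown alone.

Working notes on the series.

Compound 2 `CCOc1cc(C(=CC#N)c2ccc(OC)c(OC)c2)ccc1OC` in a functional assay on HCT-116 cells (Homo sapiens) for cytotoxicity, read by scintillation counting and thymidine incorporation, with a stated time of 72 h (on this read-out higher numbers stand for weaker inhibition and lower numbers for stronger inhibition), gives 200 nM. Compound 1 `CCOc1cc(C(=CC#N)c2ccc(OC)c(N)c2)ccc1OC` differs by one change, (amino in place of methoxy on an aromatic carbon), and the measured step is an 11-fold lower number from compound 2 to compound 1 (1.02 log units; beyond the scatter). Compound 3 `COc1ccc(C(=CC#N)c2cc(OC)c(OC)c(OC)c2)cc1OC` is built on a different core; the difference between the two cores is not broken down here. In this assay compound 3 gives 41 nM, while compound 1 gives 19 nM in this assay, so compound 3 stands between the other two measured compounds.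

Compound 4 `COc1ccc(C(=CC#N)c2cc(OC)c(OC)c(OC)c2)cc1N` applies the same change to compound 3, namely (amino in place of methoxy on an aromatic carbon); the place description is identical to the earlier change, so this is the same change on a different core.

Within the data shown here, the expected step is an 8.2-fold lower number from compound 3 to compound 4 (0.91 log units; beyond the scatter), set a little short of the single measured instance, because an 11-fold lower number from compound 2 to compound 1 (1.02 log units; beyond the scatter) is the only measured step of this kind and the core differs. The estimate for compound 4 is 5 nM, expected between 1.5 nM and 16 nM.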

Compound 4, half-maximal inhibitory concentration: 1.8 nM
Compound 4: middle estimate off by 2.8-fold (0.44 log units), on the high side; low and high end bracket the measured number.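

In this assay, amino in place of methoxy on an aromatic carbon gives a 23-fold lower number from compound 3 to compound 4 (1.36 log units; beyond the scatter), and the size of the step does not separate the two cores: the same change on two cores in this assay, an 11-fold lower number (1.02 log units; beyond the scatter) from compound 2 to compound 1 and a 23-fold lower number (1.36 log units; beyond the scatter) from compound 3 to compound 4, 2.2-fold (0.34 log units) apart, within the scatter of two such steps. The change therefore carries across these two cores, lowering the number by a comparable amount on each. Two pairs do not show that it would carry to any further core, and they do not explain why the number falls.

Still open, going by these compounds, is whether amino itself is required, or whether a hydroxyl, a methylamino or an acetamide group in the same place would do as well. Also open, on these data alone, is how the series would respond to a carboxylic acid in place of the nitrile.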